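The source may report more compounds than this note shows. Statements on the series, on what has been measured and on what is new or still open speak of the compounds shown alone.

Measured so far in an assay for inhibition of histone deacetylase 8 (Homo sapiens), read by fluorescence, with stated times of 15 min and 60 min; on this read-out higher numbers stand for weaker inhibition and lower numbers for stronger inhibition:

Compound 1 `Nc1ccccc1NC(=O)c1ccc(CNC2=N[C@@H](Cc3ccccc3)CS2)cc1` gives 34900 nM.
Compound 2 `Nc1cc(-c2ccccc2)ccc1NC(=O)c1ccc(CNc2nccc(-c3cccnc3)n2)cc1` gives > 20000 nM; this is a limit of the assay, not a number.
Compound 3 `CC(=O)N1C(NCc2ccc(C(=O)Nc3ccccc3N)cc2)=NC(=O)C1Cc1ccccc1` gives 22700 nM.

Among the compounds with values here, compound 2 stands at the limit of > 20000 nM in this assay, at which 1 of the 3 values shown sits, so in this assay only an upper bound on its inhibition is known, and no measured step leads from it to any other compound.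

Compound 4 `CC(C)(C)[Si](C)(C)OCc1ccc(NC(=O)c2ccc(CNc3nccc(-c4cccnc4)n3)cc2)c(N)c1` is the next compound to be run in this assay. Compared with compound 2 the change is a group of 9 heavy atoms (7 carbon, 1 oxygen, 1 silicon; no ring) in place of a group of 6 heavy atoms (6 carbon; one six-membered aromatic ring of carbon only), on an aromatic carbon, in words: a group of 9 heavy atoms (7 carbon, 1 oxygen, 1 silicon; no ring) in place of a group of 6 heavy atoms (6 carbon; one six-membered aromatic ring of carbon only), on an aromatic carbon.

With compound 2 already at the limit, the expected step from compound 2 to compound 4 in this assay is a step that the limit leaves unreadable from compound 2 to compound 4, that is, none beyond the scatter in either direction. Compound 4 is therefore expected to come out near 30000 nM, within a range from 10000 nM to 100000 nM, with a good chance that the assay again reports only a limit.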

Compound 4, half-maximal inhibitory concentration: > 20000 nM
Compound 4 was reported as a limit (the forecaster's own chance of this, stated with the estimate: 60%); the middle value lies beyond the limit too.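

Compound 2 and compound 4 are both reported only as limits in this assay, so no step between them can be read: the limit of > 20000 nM in this assay, at which 2 of the 4 values shown sit.

The compounds shown leave open how strongly either compound inhibits, and whether exchanging the phenyl for the silicon-bearing group changes inhibition at all.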